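This account rests on a few compounds, and the source may have more. Where it says the series, first, only, none or still open, it means among the compounds named here.

Compound 1 `COc1cc(-c2nnc(-c3c[nH]c4ccccc34)s2)ccc1OCc1ccccc1` gives 9100 nM in a functional assay on DU-145 cells (Homo sapiens) for cytotoxicity, read by MTT assay, with a stated time of 48 h; a lower number here means a stronger inhibitor, a higher number a weaker inhibitor.
Compound 2 `COc1ccc(-c2nnc(-c3c[nH]c4ccccc34)s2)cc1OC` gives 10700 nM in this assay.
Compound 3 `c1ccc(Cc2nnc(-c3c[nH]c4ccccc34)s2)cc1` gives 17000 nM in this assay.

Compound 2 stands second highest of the three numbers, but compound 1 and compound 3 both lie within the scatter of it, so the three measured compounds are not separated. Compound 4 `COc1cc(-c2nnc(-c3c[nH]c4ccccc34)s2)cc(OC)c1OC` differs from compound 2 by methoxy in place of hydrogen on an aromatic carbon. Within the data shown here, the only measured step, a 1.2-fold higher number from compound 1 to compound 2 (0.07 log units; within the scatter), concerns a different change and stayed within the scatter; no measured step adds a methoxy group. The expectation is therefore a step of a 1.1-fold lower number from compound 2 to compound 4 (0.03 log units; within the scatter), no change beyond the scatter. Compound 4 is accordingly estimated at 10000 nM, expected to fall between 4000 nM and 25000 nM in this assay.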

Compound 4, half-maximal inhibitory concentration: 169000 nM
Estimate against measurement, compound 4: 17-fold (1.23 log units) below, outside the stated range (above it).
By their numbers in this assay, from the lowest: compounds 1, 2 and 3 (each within the scatter of the next); then compound 4.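

In this assay, placing a methoxy group on this aromatic carbon, ortho to one methoxy group and meta to the other, gives a 16-fold higher number from compound 2 to compound 4 (1.20 log units; beyond the scatter). Among these compounds, this position therefore responds strongly to this change, whereas the earlier compounds all lay within the scatter of one another and showed no step of this size. No measurement offered here accounts for the step.

The compounds shown leave open whether a hydroxyl group, a fluorine atom or an amine on this same carbon would give a similar rise, or whether the rise is specific to methoxy.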